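Amide Variation at the Carbonyl of a Naphthol Core

The source may hold more compounds than are shown below. What is called first, only, known or untested is meant among the compounds shown, and "the series" means these compounds.

Measured compounds in an assay on LtK cells with ATP-sensitive inward rectifier potassium channel 11 (Homo sapiens) as the target; on this read-out higher numbers stand for an effect only at larger amounts of compound and lower numbers for an effect already at smaller amounts:
- compound 1, `O=C(CCc1ccccc1)Nc1c(C(O)(C(F)(F)F)C(F)(F)F)ccc2ccccc12`: 1750 nM
- compound 2, `CC(C)OC(=O)Nc1c(C(O)(C(F)(F)F)C(F)(F)F)ccc2ccccc12`: 1160 nM
- compound 3, `O=C(Nc1c(C(O)(C(F)(F)F)C(F)(F)F)ccc2ccccc12)c1ccccc1Cl`: 2040 nM

All three compounds share one core and differ only in the group attached to the carbonyl carbon of the amide. The numbers they give in this assay lie close together: the step of a 1.2-fold higher number from compound 1 to compound 3 (0.07 log units; within the scatter) and the step of a 1.8-fold higher number from compound 2 to compound 3 (0.25 log units; within the scatter) both stay within the usual scatter, as does the step of a 1.5-fold lower number from compound 1 to compound 2 (0.18 log units; within the scatter). On the data so far, exchanging phenethyl, isopropoxy or 2-chlorophenyl at this position has not moved the read-out beyond what repeated measurements would show anyway.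

Compound 4, `Cc1cccc(C(=O)Nc2c(C(O)(C(F)(F)F)C(F)(F)F)ccc3ccccc23)c1`, takes this series one step further: 3-methylphenyl in place of 2-chlorophenyl on a carbonyl carbon. The three measured steps all bear on this change, since each of them also swaps the group on the carbonyl carbon, and none of them was larger than the scatter. The expectation for compound 4 is therefore a step of about a 1.1-fold lower number from compound 3 to compound 4 (0.05 log units; within the scatter) in this assay, that is, no change beyond the scatter in either direction. Compound 4 is estimated at 1800 nM in this assay, with a range from 900 nM to 3600 nM.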

Compound 4, half-maximal effective concentration: 23 nM
For compound 4 the middle estimate is 78-fold (1.89 log units) above the measured one; the measured number lies below the stated range.
By their numbers in this assay, from the lowest: compound 4; then compounds 2, 1 and 3 (each within the scatter of the next).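

In this assay, the group on the carbonyl carbon proves able to change the read-out strongly, which the close values of the phenethyl, isopropoxy and 2-chlorophenyl compounds had not shown: 3-methylphenyl gives an 89-fold lower number from compound 3 to compound 4 (1.95 log units; beyond the scatter), and the comparisons with the other two groups give a 50-fold lower number from compound 2 to compound 4 (1.70 log units; beyond the scatter) and a 76-fold lower number from compound 1 to compound 4 (1.88 log units; beyond the scatter). The step from 2-chlorophenyl to 3-methylphenyl is also a modest one on paper, since both groups have the same heavy-atom count, one six-membered aromatic ring of carbon only, no hydrogen-bond donors or acceptors and no net charge, so these simple counts do not separate two compounds that the assay separates widely. Nothing available here accounts for the size of this difference.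

The exchange removes a chlorine and adds a methyl at a different place on the ring, so the compounds shown cannot say whether the lower number goes with the methyl, with its place, or with the loss of the chlorine. A plain phenyl, 2-methylphenyl and 3-chlorophenyl at the same carbonyl carbon would pull these apart, and 3-ethylphenyl would show whether a longer chain at that place is compatible with the low number.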